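The compounds below may be only part of what the source reports. "The series", "measured", "known", "first", "only" and "open" are said of these compounds alone.

Three esters of the shared core have been measured in an assay for inhibition of 3-hydroxy-3-methylglutaryl-coenzyme A reductase (Rattus norvegicus); on this read-out higher numbers stand for weaker inhibition and lower numbers for stronger inhibition. Compound 1 `C[C@H]1C=C2C=C[C@H](C)[C@H](CC[C@@H]3C[C@@H](O)CC(=O)O3)C2[C@@H](OC(=O)C2CC2)C1` gives 38.6 nM. Compound 2 `C=C(C)CC(=O)O[C@H]1C[C@@H](C)C=C2C=C[C@H](C)[C@H](CC[C@@H]3C[C@@H](O)CC(=O)O3)C21` gives 2.9 nM, and compound 3 `CC(CC(=O)O[C@H]1C[C@@H](C)C=C2C=C[C@H](C)[C@H](CC[C@@H]3C[C@@H](O)CC(=O)O3)C21)C(F)(F)F` gives 3.5 nM. Compound 3 stands second highest of the three numbers, nearest to compound 2 and furthest from compound 1; the steps of a 13-fold lower number from compound 1 to compound 2 (1.12 log units; beyond the scatter) and an 11-fold lower number from compound 1 to compound 3 (1.04 log units; beyond the scatter) were both large, whereas a 1.2-fold higher number from compound 2 to compound 3 (0.08 log units; within the scatter) lay within the scatter.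

Compound 4 `C[C@H]1C=C2C=C[C@H](C)[C@H](CC[C@@H]3C[C@@H](O)CC(=O)O3)C2[C@@H](OC(=O)c2ccc(F)cc2)C1` carries the change (4-fluorophenyl in place of 2-(trifluoromethyl)propyl on a carbonyl carbon). The two large steps from compound 1 bear on it only indirectly: each replaced the cyclopropyl, which has a ring, by a chain without one, and compound 4 returns to a ring, now aromatic. Within the data shown here, no measured step pairs an aromatic ester with any of the three. Some movement back towards the number of compound 1 is expected rather than a further gain, with wide uncertainty. For compound 4 the estimate in this assay is 15 nM, within 3 nM to 60 nM. This expected step is a 4.3-fold higher number from compound 3 to compound 4 (0.63 log units; beyond the scatter).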

Compound 4, half-maximal inhibitory concentration: 37 nM
Compound 4: the middle estimate sits 2.5-fold (0.39 log units) below what was measured, and the stated range covers the measured number.
By their numbers in this assay, from the lowest: compounds 2 and 3 (each within the scatter of the next); then compounds 4 and 1 (each within the scatter of the next).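

In this assay the 4-fluorophenyl ester does not keep the level of the two open-chain esters: there is an 11-fold higher number from compound 3 to compound 4 (1.02 log units; beyond the scatter) and a 13-fold higher number from compound 2 to compound 4 (1.11 log units; beyond the scatter), both large, whereas a 1.0-fold lower number from compound 1 to compound 4 (0.02 log units; within the scatter) lies within the scatter. At this place on the carbonyl carbon, the four compounds therefore fall into two groups, with the ring-bearing cyclopropyl and 4-fluorophenyl esters together and the 2-methylprop-2-en-1-yl and 2-(trifluoromethyl)propyl esters together, and none of the four goes against this split. The aromatic ring and the cyclopropyl ring are not told apart on this read-out, and nothing available explains the split between ring and chain esters.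

Whether the ring itself sets the level remains open, as only two rings and two chains are shown. A cyclohexyl ester, an unsubstituted phenyl ester and a longer open chain such as pentyl would test how far the split holds.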